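The source may report more compounds than this note shows. Statements on the series, on what has been measured and on what is new or still open speak of the compounds shown alone.

Within the data shown here, in a functional assay on A549 cells (Homo sapiens) for cytotoxicity, read by MTT assay, with a stated time of 72 h (on this read-out higher numbers stand for weaker inhibition and lower numbers for stronger inhibition), compound 1 (`COc1ccc(/C=C/C(=O)Nc2cc3c(Nc4ccc(F)c(Cl)c4)ncnc3cc2O[C@H]2CCOC2)c(OC)c1`) gives 9350 nM, the lower of the only two numbers available. Compound 3 (`COc1cc2ncnc(Nc3ccc(F)c(Cl)c3)c2cc1NC(=O)/C=C/c1ccccc1[N+](=O)[O-]`) gives 33300 nM, a higher number than that of compound 1, and the gap lies beyond the usual scatter. Compound 2 (`COc1ccc(/C=C/C(=O)Nc2cc3c(Nc4ccc(F)c(Cl)c4)ncnc3cc2OC)cc1`) is reported as "not active" (no number reported), with no number attached.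

Compound 4 (`N#Cc1ccc(/C=C/C(=O)Nc2cc3c(Nc4ccc(F)c(Cl)c4)ncnc3cc2O[C@H]2CCOC2)cc1`) has not yet been measured. It keeps everything in compound 1 except one group: 4-cyanophenyl in place of 2,4-dimethoxyphenyl on a double-bonded chain carbon bound to a double-bonded chain carbon. Put simply, 4-cyanophenyl stands in place of 2,4-dimethoxyphenyl on a double-bonded chain carbon bound to a double-bonded chain carbon.

Among the measured compounds shown here, no two measured compounds differ in just one place, so the data do not directly show what a single swap of this kind does in this assay. For the measured compounds named here, compound 1 holds the lowest number so far, while compound 3 gives 33300 nM and compound 2 gives no number, so any move is expected to be toward a higher number. The expected size of a 1.3-fold higher number from compound 1 to compound 4 (0.11 log units; within the scatter) is modest and is estimated to stay within the scatter. For compound 4, the estimated value is 12000 nM, with an expected range of 4000 nM to 35000 nM.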

Compound 4, half-maximal inhibitory concentration: "not active" (no number reported)
Compound 4: no number reported, so the estimate cannot be set against anything.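

In this assay, among these compounds, compound 4 has no number, so no step from compound 1 to compound 4 can be read, and no measured property bears on this result. The compounds shown leave open how much replacing 2,4-dimethoxyphenyl with 4-cyanophenyl alone changes the number in this assay when all else stays the same.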